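This account rests on a few compounds, and the source may have more. Where it says the series, first, only, none or still open, it means among the compounds named here.

Three compounds have been measured in an ADME assay on Caco-2 cells (Homo sapiens) for permeability, in the apical to basolateral direction, at pH 7.4; on this read-out lower numbers stand for lower permeability and higher numbers for higher permeability:

compound 1 `O=C(N[C@H]1CN(S(=O)(=O)c2ccccc2)C[C@@H]1C(=O)N[C@H]1CCCNC1)c1cc(-c2ccccc2Cl)on1`: 0.31 10^-6 cm/s
compound 2 `Cc1oc(-c2ccccc2Cl)nc1C(=O)N[C@H]1CN(S(=O)(=O)c2ccccc2)C[C@@H]1C(=O)N[C@H]1CCCNC1`: 0.13 10^-6 cm/s
compound 3 `CN(C(=O)c1cc(-c2ccccc2Cl)on1)[C@H]1CN(S(=O)(=O)c2ccccc2)C[C@@H]1C(=O)N[C@H]1CCCNC1`: 0.06 10^-6 cm/s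

Compound 3 has the lowest number of the three, and compound 1 has the highest. Compound 4 `CN(C(=O)[C@H]1CN(S(=O)(=O)c2ccccc2)C[C@@H]1N(C)C(=O)c1cc(-c2ccccc2Cl)on1)[C@H]1CCCNC1` differs from compound 3 by a single change, (methyl in place of hydrogen on an amide-type nitrogen), which puts methyl in place of hydrogen on an amide-type nitrogen. Within the data shown here, one measured step bears on this, the same replacement on another amide-type nitrogen: a 5.2-fold lower number from compound 1 to compound 3 (0.71 log units; beyond the scatter). This single precedent suggests a further fall in this assay of modest size, though perhaps a smaller one. The expected step is a 2.0-fold lower number from compound 3 to compound 4 (0.30 log units; within the scatter). For compound 4 the estimated value is 0.03 10^-6 cm/s, within an expected range of 0.01 10^-6 cm/s to 0.09 10^-6 cm/s.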

Compound 4, apparent permeability in the Caco-2 assay: 0.075 10^-6 cm/s
Compound 4: the middle estimate sits 2.5-fold (0.40 log units) below what was measured, and the stated range covers the measured number.
By their numbers in the Caco-2 assay, from the lowest: compounds 3, 4 and 2 (each within the scatter of the next, the first and the last beyond it); then compound 1.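

In the Caco-2 assay compound 3 gives 0.06 10^-6 cm/s and compound 4 gives 0.075 10^-6 cm/s. In the Caco-2 assay methyl in place of hydrogen on the amide-type nitrogen whose other neighbours are a carbonyl carbon and a saturated ring carbon gives a 1.3-fold higher number from compound 3 to compound 4 (0.10 log units; within the scatter) and so does not repeat a 5.2-fold lower number from compound 1 to compound 3 (0.71 log units; beyond the scatter) on the other amide-type nitrogen. In a physicochemical assay for solubility, at pH 7.4 (a higher number here means a more soluble compound, a lower number a less soluble compound), compound 3 gives 655000 nM and compound 4 gives 553000 nM. In the physicochemical assay the same change gives a 1.2-fold lower number from compound 3 to compound 4 (0.07 log units; within the scatter) and so shows no shift there either. No evidence at hand accounts for the difference between the two replacements. The compounds shown leave open whether ethyl or a longer chain on this nitrogen would give a step beyond the scatter in either read-out.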